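Anilinoacetamide lactones: removing one chloro from compound 1

The source may report more compounds than this note shows. Statements on the series, on what has been measured and on what is new or still open speak of the compounds shown alone.

The series shares a lactone amide core. Compound 1 `O=C(CNc1ccc(Cl)cc1Cl)N[C@H]1CCOC1=O` carries two chloro groups on its aniline ring. In a functional assay on MGC-803 cells (Homo sapiens) for antiproliferative activity, read by MTT assay, with a stated time of 72 h (on this read-out higher numbers stand for weaker inhibition and lower numbers for stronger inhibition), compound 1 gives only a limit, > 64000 nM, not a number. Compound 2 `O=C(CNc1cccc(Cl)c1)N[C@H]1CCOC1=O` carries a single chloro. In this assay compound 2 likewise gives only a limit, > 64000 nM. Compound 3 `O=C(COc1ccc(C(=O)/C=C/c2cccc(F)c2)cc1)N[C@H]1CCOC1=O` replaces the anilino link with an aryloxy chalcone. In this assay compound 3 also reaches only a limit, > 64000 nM. Every value shown therefore sits at the limit of > 64000 nM in this assay, at which 3 of the 3 values shown sit, and compound 1 stands nowhere distinct: no number separates it from compound 2 or compound 3.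

Compound 4 `O=C(CNc1ccc(Cl)cc1)N[C@H]1CCOC1=O` is not yet measured. Relative to compound 1 the change is hydrogen in place of chloro on an aromatic carbon. Among the compounds with values here, no step between measured compounds exists to size this change. A step of none beyond the scatter is expected, most probably again ending at the limit, because all three values shown sit at the limit of > 64000 nM in this assay, at which 3 of the 3 values shown sit. The expected step is a step that the limit leaves unreadable from compound 1 to compound 4. Compound 4 is expected to give 80000 nM in this assay, within an estimated range of 40000 nM to 200000 nM, and very probably to be reported only as a limit.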

Compound 4, half-maximal inhibitory concentration: > 64000 nM
Compound 4 gave a limit, no number; the forecaster's own chance of this, stated with the estimate: 85%; the middle value lies beyond the limit too.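

In this assay compound 4 gives only a limit, > 64000 nM, and compound 1 also gives only a limit, so the step between compound 1 and compound 4 cannot be read: the limit of > 64000 nM in this assay, at which 4 of the 4 values shown sit.

The compounds shown leave open whether any variation on the shared core gives a number in this assay.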